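Bromo for ethyl on the aryl ring of compound 1

A few compounds are considered here, and "the series" means these few. Any claim that something is new, unique, unknown or untested is made for them only; others in the source may bear on it.

Measured compounds:
compound 1, `CCc1ccc(N2C(=O)C=CC2OCC(F)(F)F)cc1`, 7840 nM
compound 2, `O=C1C=CC(OC(C(F)(F)F)C(F)(F)F)N1c1ccc(Cl)cc1`, 2410 nM
compound 3, `O=C1C=CC(OCC(F)(F)F)N1c1ccc(Cl)cc1F`, 6100 nM

These three compounds were tested in a functional assay on MDA-MB-231 cells (Homo sapiens) for inhibition; a higher number here means a weaker inhibitor, a lower number a stronger inhibitor. Compound 1 gives the highest number of the three, 7840 nM. Compound 3 sits closest to it with 6100 nM, a gap within the scatter, so the two cannot be told apart. Compound 2, with 2410 nM, stands furthest away and gives a number beyond the scatter lower than compound 1. For the measured compounds named here, compounds 2 and 3 differ from compound 1 in more than one place, so no single step between measured compounds is available to lean on.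

The step to compound 4, `O=C1C=CC(OCC(F)(F)F)N1c1ccc(Br)cc1`, changes one thing: bromo in place of ethyl on an aromatic carbon. The shared core and the trifluoroethyl ether stay as in compound 1.

Since compound 2 and compound 3 each carry a chloro where compound 1 carries ethyl, and neither gives a higher number than compound 1, a modest move toward a lower number is expected for a 1.6-fold lower number from compound 1 to compound 4 (0.20 log units; within the scatter), possibly still within the scatter. Compound 4 is therefore estimated at 5000 nM, with a range from 2000 nM to 12000 nM.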

Compound 4, half-maximal inhibitory concentration: 7570 nM
For compound 4 the middle estimate is 1.5-fold (0.18 log units) below the measured one; the range from low to high includes it.
By their numbers in this assay, from the lowest: compound 2; then compounds 3, 4 and 1 (each within the scatter of the next).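

In this assay, bromo in place of ethyl on an aromatic carbon, para to a large group, gives a 1.0-fold lower number from compound 1 to compound 4 (0.02 log units; within the scatter), so this assay does not tell the two groups apart at this position. For the compounds shown here, this is the first direct comparison at this position, as the earlier compounds differed from one another in more than one place and could not isolate the effect of a single group. Here, a group of 2 carbon atoms and a single bromine atom give matching results, which suggests that, for this pair, the change in heavy-atom count does not register in the read-out, and no measurement shown here gives a reason for this match.

On these data alone, whether an amine, a carboxylic acid or a longer chain on the same aromatic carbon would also leave the number within the scatter remains open, since only ethyl and bromo can be compared directly there. Also open is how far a different ether would shift the number with the aryl ring held fixed, as no pair shown changes the trifluoroethyl ether alone.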